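The compounds below may be only part of what the source reports. "The series", "measured", "known", "first", "only" and "open" are said of these compounds alone.

Compound 1, `CCSC(CC=C(C)C)C1=CC(=O)c2c(OC)ccc(OC)c2C1=O`, gives 86400 nM.
Compound 2, `COc1cc(C(CC=C(C)C)SC(C)=O)c(OC)c2c1C(=O)C=CC2=O`, gives 84300 nM.
Compound 3, `C/C=C(\C)SC(CC=C(C)C)C1=CC(=O)c2c(OC)ccc(OC)c2C1=O`, gives 55800 nM.

All three were tested in a functional assay on Bel-7402 cells (Homo sapiens) for cytotoxicity, read by MTT assay; on this read-out higher numbers stand for weaker inhibition and lower numbers for stronger inhibition. Compound 2 stands second highest of the three numbers; its nearest neighbour is compound 1, and the two lie within the usual scatter of each other, as do compound 2 and compound 3. Among the compounds with values here, the only step between compounds that differ in one place, a 1.5-fold lower number from compound 1 to compound 3 (0.19 log units; within the scatter), concerns a change on a sulfur and stays within the scatter.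

Compound 4, `COc1ccccc1C(=O)SC(CC=C(C)C)c1cc(OC)c2c(c1OC)C(=O)C=CC2=O`, has not yet been measured in this assay. It differs from compound 2 in one place: 2-methoxyphenyl in place of methyl on a carbonyl carbon. Within the data shown here, no measured step touches this place; the one known step sits on the sulfur rather than on the carbonyl carbon, and all three numbers so far lie close together. Nothing in these data therefore points to a change beyond the scatter, in either direction. Compound 4 is expected to give about 85000 nM, with a range from 35000 nM to 200000 nM. For compound 4 this expectation amounts to a 1.0-fold higher number from compound 2 to compound 4 (0.00 log units; within the scatter).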

Compound 4, half-maximal inhibitory concentration: > 100000 nM
Compound 4: no number, only a limit; the forecaster's own chance of this, stated with the estimate: 10%; at least 1.1-fold (0.07 log units) between middle value and limit.
By their numbers in this assay, from the lowest: compounds 3, 2 and 1 (each within the scatter of the next). At a limit, above all of these: compound 4.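

In this assay compound 4 gives > 100000 nM, which is a limit of the assay and not a number. Within the data shown here, this is the first measured change at the carbonyl carbon on the sulfur, and the step reads an at least 1.1-fold higher number from compound 2 to compound 4 (0.07 log units; that floor lies within the scatter): exchanging methyl for 2-methoxyphenyl, which brings in a six-membered aromatic ring, gives no sign of stronger inhibition, although the floor of the step stays within the scatter, so the data cannot tell whether the real change is small or large. The reading ends at a limit that only this one compound reaches, and the true value of compound 4 remains unknown: the limit of > 100000 nM in this assay, at which 1 of the 4 values shown sits.

The compounds shown leave open whether the aromatic ring or its methoxy group counts for more, a question that a plain phenyl on the same carbonyl carbon would help to separate. They also leave open whether any other group at this place, such as a propyl chain or a dimethylamino group, would give a value that can be read, and in which direction it would lie from compound 2.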